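From methoxy to nitro on compound 2

This account rests on a few compounds, and the source may have more. Where it says the series, first, only, none or still open, it means among the compounds named here.

Of the compounds shown here, three have been measured in a functional assay on MC-38 cells (Mus musculus) for antiproliferative activity, read by colorimetric assay and MTT assay; a higher number here means a weaker inhibitor, a lower number a stronger inhibitor. Compound 1 `COc1ccc(S(=O)(=O)Nc2cccc3cc[nH]c23)cc1` gives 1.5 ug/mL, compound 2 `COc1ccc(S(=O)(=O)Nc2ccc(Cl)c3cc[nH]c23)cc1` gives 0.65 ug/mL, and compound 3 `O=S(=O)(Nc1cc(Cl)cc2cc[nH]c12)c1ccc(Cl)cc1` gives 8.5 ug/mL. Compound 2 therefore holds the lowest number of the three.

The next comparison starts from compound 2 and leads to compound 4 `O=[N+]([O-])c1ccc(S(=O)(=O)Nc2ccc(Cl)c3cc[nH]c23)cc1`, with nitro in place of methoxy on an aromatic carbon, para to a large group (nitro in place of methoxy on an aromatic carbon).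

Within the data shown here, the only measured single-place step is a 2.3-fold lower number from compound 1 to compound 2 (0.36 log units; beyond the scatter), chloro in place of hydrogen on an aromatic carbon. It is modest and involves a different change, so it offers only a rough sense of scale. Among the measured compounds shown here, compound 2 and compound 3 differ in more than one place, so they provide no clean step. Even so, compound 3, which also lacks methoxy, stands at 8.5 ug/mL, and this favours a higher number rather than a lower one. For the measured compounds named here, no measured compound carries nitro, so the uncertainty is wide.

A modest move towards a higher number is expected in this assay, with an estimated 2.3-fold higher number from compound 2 to compound 4 (0.36 log units; beyond the scatter). For compound 4 the estimated value is 1.5 ug/mL, with an expected range from 0.4 ug/mL to 6 ug/mL.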

Compound 4, half-maximal inhibitory concentration: 0.67 ug/mL
Compound 4: middle estimate off by 2.2-fold (0.35 log units), on the high side; the measured number falls inside the stated range.
By their numbers in this assay, from the lowest: compounds 2 and 4 (each within the scatter of the next); then compound 1; then compound 3.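

In this assay, replacing methoxy with nitro on the carbon para to a large group gives a 1.0-fold higher number from compound 2 to compound 4 (0.01 log units; within the scatter), so the two groups cannot be told apart at this place on the background of compound 2. Among these compounds, this is the first reading of a change at this position, since the only earlier clean step concerned chloro in place of hydrogen on the other side of the sulfonamide and left methoxy untouched; it shows that the position accepts two quite different groups, with different atoms and counts of hydrogen-bond acceptors, without a readable shift in the number. There is no evidence to explain why the two groups read alike in this assay.

Among the compounds shown here, the result covers only this pair on one background, so it remains open whether nitro and methoxy would also read alike on the core of compound 1, without the chloro. It also leaves open whether this tolerance extends to an amine, a carboxylic acid or a longer chain such as butoxy at the same carbon.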